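Iodo in place of hydrogen on the benzoyl ring

The compounds below may be only part of what the source reports. "The series", "measured", "known", "first", "only" and "open" are said of these compounds alone.

Measured so far:
compound 1, `CC(/C=N/Nc1ccc([N+](=O)[O-])cc1)=N\NC(=O)c1ccccc1O`: 29500 nM
compound 2, `CC(/C=N/Nc1ccc([N+](=O)[O-])cc1)=N\NC(=O)c1ccccc1`: > 100000 nM

Compound 2 sits at a limit in an ADME assay on J774 cells (Mus musculus, strain BALB/c) for cytotoxicity, read by resazurin assay, with a stated time of 72 h; on this read-out higher numbers stand for lower toxicity in this test and lower numbers for higher toxicity in this test: its value of > 100000 nM is the limit of the assay and not a number (the limit of > 100000 nM in this assay, at which 1 of the 2 values shown sits). Among the measured compounds shown here, the only measured step, an at least 3.3-fold higher number from compound 1 to compound 2 (0.53 log units; beyond the scatter), is hydrogen in place of hydroxy on an aromatic carbon. The next compound, compound 3, `CC(/C=N/Nc1ccc([N+](=O)[O-])cc1)=N\NC(=O)c1ccccc1I`, differs from compound 2 by iodo in place of hydrogen on an aromatic carbon, a change on an aromatic carbon of a six-membered aromatic ring of carbon only. For the measured compounds named here, no measured step covers iodo in place of hydrogen, so the measured step gives no direction for it; compound 2 already stands at the limit, and a further rise could not be read. The expectation for compound 3 is therefore a number near the limit, with an at least 1.1-fold lower number from compound 2 to compound 3 (0.04 log units; that floor lies within the scatter) expected to stay within the scatter. Compound 3 is estimated at 90000 nM, from 30000 nM to 250000 nM.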

Compound 3, half-maximal cytotoxic concentration: 40000 nM
Compound 3: middle estimate off by 2.3-fold (0.35 log units), on the high side, within the range that was stated.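

In this assay, among the compounds shown here, hydroxy is no longer the only group at this position on the six-membered aromatic ring of carbon only that goes with a lower number than hydrogen, with an at least 2.5-fold lower number from compound 2 to compound 3 (0.39 log units; beyond the scatter). Iodo and hydroxy are not told apart at this position, with a 1.4-fold higher number from compound 1 to compound 3 (0.13 log units; within the scatter), which lies within the scatter. For compound 2, the value of > 100000 nM is a limit and not a number, and the step to iodo carries only a floor: the limit of > 100000 nM in this assay, at which 1 of the 3 values shown sits.

On these data alone, whether the lower number goes with any group other than hydrogen at this position, or only with hydroxy and iodo, stays open. Fluoro, chloro, methoxy or an amine at the same carbon could separate these readings, and the true size of the step from hydrogen remains unknown.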